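Thiophene-trimming step in an imidazothiazole hydrazone series

A few compounds are considered here, and "the series" means these few. Any claim that something is new, unique, unknown or untested is made for them only; others in the source may bear on it.

Measured compounds:
Compound 1 `Cc1cc(-c2nc3sc(C)cn3c2/C=N/NC(=N)N)c(C)s1`: in a functional assay on cells (Cancer cell lines, Homo sapiens) for inhibition (on this read-out higher numbers stand for weaker inhibition of growth and lower numbers for stronger inhibition of growth), compound 1 gives 11700 nM
Compound 2 `Cc1cn2c(/C=N/Nc3ccccn3)c(-c3ccc(Cl)c([N+](=O)[O-])c3)nc2s1`: in this assay compound 2 gives 42700 nM

Compound 1 stands at the lowest of the two numbers in this assay; the gap to compound 2 lies beyond the usual scatter, but compound 2 differs from compound 1 at more than one place, so no single change can be read from the pair.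

Compound 3 `Cc1cn2c(/C=N/NC(=N)N)c(-c3ccsc3)nc2s1` is not yet measured. It differs from compound 1 by thiophen-3-yl in place of 2,5-dimethylthiophen-3-yl on an aromatic carbon. Among the measured compounds shown here, no measured pair shows a change of this kind, so the expected size of the step in this assay rests on judgment alone: a small step, if any, with the direction open and most likely not beyond the scatter, leaning slightly toward weaker inhibition. On that basis compound 3 is estimated at 18000 nM in this assay, within a range of 6000 nM to 55000 nM, which means an expected step of a 1.5-fold higher number from compound 1 to compound 3 (0.19 log units; within the scatter).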

Compound 3, concentration for total growth inhibition: 20400 nM
Estimate against measurement, compound 3: 1.1-fold (0.05 log units) below; the range from low to high includes it.
By their numbers in this assay, from the lowest: compounds 1 and 3 (each within the scatter of the next); then compound 2.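

In this assay the position on the core now has a single-place step, thiophen-3-yl in place of 2,5-dimethylthiophen-3-yl (a 1.7-fold higher number from compound 1 to compound 3 (0.24 log units; within the scatter)), and that step stays within the scatter. At this position, the thiophene therefore keeps the level of growth inhibition seen with compound 1 without its methyl groups, so these groups show no measurable contribution on this read-out. No measurement at hand accounts for the size of this step.

Open, from the compounds shown here alone, is whether this position stays as flat when the thiophene carries something other than methyl, such as a primary amine, a carboxylic acid or an n-butyl chain. Also open, going by these compounds, is whether replacing the thiophene itself with a phenyl ring would move the number beyond the scatter.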